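This account rests on a few compounds, and the source may have more. Where it says the series, first, only, none or still open, it means among the compounds named here.

Measured compounds:
compound 1 `CC1=CC[C@H](C(C)C)c2cc(C)c(OC(=O)Nc3ccccc3)cc21`: 75.1%
compound 2 `CC1=CC[C@H](C(C)C)c2cc(C)c(OC(=O)c3ccc(C(F)(F)F)cc3)cc21`: 40.4%
compound 3 `CC1=CC[C@H](C(C)C)c2cc(C)c(OC(=O)c3ccc(Cl)cc3)cc21`: 79.7%

All three share one core and differ only in the group attached to the carbonyl carbon. In a functional assay on MCF7 cells (Homo sapiens) for antiproliferative activity, read by sulforhodamine B assay, with a stated time of 48 h, tested at 50 uM (on this read-out lower numbers stand for less inhibition and higher numbers for more inhibition at the one concentration tested (going by the name of the read-out)), compound 3 gives 79.7%, the highest of the three numbers, although its gap to compound 1 is within the scatter, so the two cannot be ranked against each other. The step from the anilino compound was a number 4.6 percentage points higher from compound 1 to compound 3 (within the scatter), whereas exchanging one group on the aromatic ring gave a number 39.3 percentage points higher from compound 2 to compound 3 (beyond the scatter).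

Compound 4 `CC1=CC[C@H](C(C)C)c2cc(C)c(OC(=O)c3cccc([N+](=O)[O-])c3)cc21` is not yet measured. Its change from compound 3 is 3-nitrophenyl in place of 4-chlorophenyl on a carbonyl carbon. Among the measured compounds shown here, no measured step involves a nitro group, so the direction cannot be read directly. For the measured compounds named here, two steps bear on it indirectly: a number 4.6 percentage points higher from compound 1 to compound 3 (within the scatter) shows that a sizeable change at the carbonyl carbon can leave the read-out unchanged, while a number 39.3 percentage points higher from compound 2 to compound 3 (beyond the scatter) shows that a single group on the aromatic ring can shift it by a large amount. The expectation is therefore uncertain, with a moderate fall of a number 24.7 percentage points lower from compound 3 to compound 4 (beyond the scatter) from compound 3 thought most likely. Compound 4 is expected to give about 55% in this assay, with a range from 30% to 80%.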

Compound 4, a percentage reported as inhibition, at one concentration (the size of the read-out at that concentration, not a potency): 29.3%
The estimate for compound 4 lay 25.7 percentage points above the measured number; the whole stated range lies above it.
By their numbers in this assay, from the lowest: compound 4; then compound 2; then compounds 1 and 3 (each within the scatter of the next).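

In this assay, putting 3-nitrophenyl in place of 4-chlorophenyl on the carbonyl carbon gives a number 50.4 percentage points lower from compound 3 to compound 4 (beyond the scatter), so keeping an aromatic ring at this carbon does not by itself keep the inhibition high. The comparison with the anilino group tells the same story, with a number 45.8 percentage points lower from compound 1 to compound 4 (beyond the scatter), so the fall holds against both of the compounds with the highest numbers, which cannot be ranked against each other. Until now, only the exchange of trifluoromethyl for chloro had shown how much the aromatic ring at this position can matter; this result adds a second large step at the same position, but nothing shown explains why the number falls.

On these data alone, the step from 4-chlorophenyl to 3-nitrophenyl changes both the group on the ring and where it sits, so it remains open whether the nitro group itself or its place on the ring matters more. As far as these compounds go, it is also open how a plain phenyl ring or a ring carrying an amine or a methoxy group would read at this carbonyl carbon, and either would give a useful reference point for the groups already compared.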